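The compounds below may be only part of what the source reports. "The series", "measured", "known", "first", "only" and "open" are said of these compounds alone.

Measured so far:
compound 1, `COc1ccc(-c2ccc(-c3ccc(C(=N)N)o3)o2)cc1`, 1890 nM
compound 2, `N=C(N)c1ccc(-c2ccc(-c3ccc(Cl)cc3)s2)s1`, 1630 nM

In a functional assay on SF-539 cells (Homo sapiens) for inhibition, read by sulforhodamine B assay, with a stated time of 48 h (a lower number here means a stronger inhibitor of growth, a higher number a weaker inhibitor of growth), compound 2 gives 1630 nM, and compound 1 gives 1890 nM; these two numbers lie within the usual scatter of each other, so neither compound can be called the stronger. Compound 3, `N=C(N)c1ccc(-c2ccc(-c3ccc(F)cc3)s2)s1`, differs from compound 2 in one place: fluoro in place of chloro on an aromatic carbon. Among the measured compounds shown here, no step between measured compounds exists that covers this exchange, so the expectation rests on compound 2 alone. A step of a 1.2-fold higher number from compound 2 to compound 3 (0.09 log units; within the scatter) is expected, that is no change beyond the scatter. Compound 3 is estimated at 2000 nM, within 800 nM to 5000 nM.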

Compound 3, concentration for 50% growth inhibition: 1670 nM
Compound 3: middle estimate off by 1.2-fold (0.08 log units), on the high side; measured number inside the range.
By their numbers in this assay, from the lowest: compounds 2, 3 and 1 (each within the scatter of the next).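

In this assay, fluoro in place of chloro on this aromatic carbon, para to a large group, gives a 1.0-fold higher number from compound 2 to compound 3 (0.01 log units; within the scatter). At this position of the six-membered aromatic ring, then, the two halogens cannot be told apart, and exchanging one for the other leaves growth inhibition unchanged within the scatter. No measured information here accounts for this.

As far as these compounds go, what an amine or a carboxylic acid would do at this position stays open. So does whether the same exchange would give so small a step on another core.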